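Replacing a carbonyl chain with 3-(4-methylpiperazin-1-yl)propyl

This account rests on a few compounds, and the source may have more. Where it says the series, first, only, none or still open, it means among the compounds named here.

- compound 1 `CN1CCN(CCC(=O)N2CC3C(c4ccccc4)CC(N(C)C)(CC3c3ccccc3)C2)CC1` gives 13000 nM
- compound 2 `CN(C)C12CC(c3ccccc3)C(CN(C(=O)CCN3CCCC3)C1)C(c1ccccc1)C2` gives 11700 nM
- compound 3 `CCN(CC)CCC(=O)N1CC2C(c3ccccc3)CC(N(C)C)(CC2c2ccccc2)C1` gives 15400 nM

These numbers come from an ADME assay on L6 cells (Rattus norvegicus) for cytotoxicity, read by resazurin assay, with a stated time of 72 h (a higher number here means a weaker inhibitor, a lower number a stronger inhibitor), and the three compounds share one core, differing only in the amine at the end of a carbonyl-bearing chain. Compound 3 stands level with the other two: a 1.2-fold higher number from compound 1 to compound 3 (0.07 log units; within the scatter) and a 1.3-fold higher number from compound 2 to compound 3 (0.12 log units; within the scatter) both lie within the scatter.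

Compound 4 `CN1CCN(CCCN2CC3C(c4ccccc4)CC(N(C)C)(CC3c3ccccc3)C2)CC1` differs from compound 3 by a larger change 3-(4-methylpiperazin-1-yl)propyl in place of (2-(diethylamino)ethyl)carbonyl on an amine nitrogen in a ring in which 3-(4-methylpiperazin-1-yl)propyl takes the place of (2-(diethylamino)ethyl)carbonyl on an amine nitrogen in a ring. Its 4-methylpiperazin-1-yl end also occurs in compound 1. The measured steps cover only the exchange of the amine end, and a 1.1-fold lower number from compound 1 to compound 2 (0.05 log units; within the scatter) shows that such exchanges stayed within the scatter too. Among the compounds with values here, no measured compound lacks the carbonyl, so that part of the change is untested and the direction is uncertain. A modest move is expected, leaning cautiously towards a lower number, with a 1.7-fold lower number from compound 3 to compound 4 (0.23 log units; within the scatter) as the estimated step. The estimate for compound 4 is 9000 nM in this assay and the expected range runs from 3000 nM to 27000 nM on either side of it.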

Compound 4, half-maximal inhibitory concentration: 200 nM
Estimate against measurement, compound 4: 45-fold (1.65 log units) above; measured number outside the range, below it.
By their numbers in this assay, from the lowest: compound 4; then compounds 2, 1 and 3 (each within the scatter of the next).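

Amine-end exchanges on the carbonyl chain had left the number in this assay essentially unchanged, but this position proves highly sensitive to the chain itself. Among the three steps, a 65-fold lower number from compound 1 to compound 4 (1.81 log units; beyond the scatter) is the most telling, since the 4-methylpiperazin-1-yl end stays in place and (2-(4-methylpiperazin-1-yl)ethyl)carbonyl becomes 3-(4-methylpiperazin-1-yl)propyl, so the carbonyl is gone while the amine end remains. The steps that also change the amine end point the same way, with a 59-fold lower number from compound 2 to compound 4 (1.77 log units; beyond the scatter) and a 77-fold lower number from compound 3 to compound 4 (1.89 log units; beyond the scatter) both large, which makes compound 4 the strongest inhibitor of the four in this cell assay, although nothing shown here accounts for the drop.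

The compounds shown leave open whether the drop belongs to the propyl chain in general or needs the 4-methylpiperazin-1-yl end, as a 3-(pyrrolidin-1-yl)propyl or 3-(diethylamino)propyl group on the same ring nitrogen would show. They also leave open how a longer chain ending in 4-methylpiperazin-1-yl would behave at this position.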